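This account rests on a few compounds, and the source may have more. Where it says the series, first, only, none or still open, it means among the compounds named here.

Working notes on a small set built on one shared core. Compound 1 `CNC(=O)c1cc(C(=O)NC2CC2)cc2c1OC[C@H]2c1ccccc1` carries a cyclopropylcarbamoyl group; compound 3 `CNC(=O)c1cc(C(=O)NC)c2c(c1)[C@H](c1ccccc1)CO2` is its methylcarbamoyl counterpart, the change being (methyl in place of cyclopropyl on an amide-type nitrogen). Compound 2 `CNC(=O)c1cc(C(=O)NC2CC2)cc2c1OC[C@@]2(C)c1ccccc1` differs from compound 1 by more than one place, and that difference between the two cores is not broken down here. Compound 4 `CNC(=O)c1cc(C(=O)NC)c2c(c1)[C@](C)(c1ccccc1)CO2` stands to compound 2 as compound 3 stands to compound 1, through (methyl in place of cyclopropyl on an amide-type nitrogen), the same change at the same place.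

In a physicochemical assay for solubility (a lower number here means a less soluble compound, a higher number a more soluble compound), compound 1 gives >= 190 ug/mL, which is a limit of the assay and not a number. In this assay compound 3 gives >= 130 ug/mL, again a limit. In this assay compound 2 gives >= 138 ug/mL, also a limit. The step that the two limits leave unreadable from compound 1 to compound 3 is therefore not readable, because both ends sit at limits, the limit of >= 190 ug/mL in this assay, at which 1 of the 3 values shown sits, and (the limit of >= 130 ug/mL in this assay, at which 1 of the 3 values shown sits). Compound 2 sits at the limit of >= 138 ug/mL in this assay, at which 1 of the 3 values shown sits, so the step to compound 4 in this assay is expected to be as unreadable as the earlier one, with a step that the limit leaves unreadable from compound 2 to compound 4 expected in the sense that the reading should again reach a limit. Compound 4 is estimated at 150 ug/mL, expected between 90 ug/mL and 250 ug/mL.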

Compound 4, solubility: >= 132 ug/mL
Compound 4: a limit, no number; the forecaster's own chance of this, stated with the estimate: 80%; the middle value does not contradict the limit.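

In this assay compound 4 gives >= 132 ug/mL, a limit of the assay and not a number. Among the compounds shown here, compound 2 and compound 4 both stand at limits, so no step between them can be read. The compounds shown leave open where the actual values of all four compounds lie, and whether methyl in place of cyclopropyl on an amide-type nitrogen shifts the reading on either core.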